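Swapping 2-chlorophenyl for 3-bromophenyl on a carbonyl carbon

A few compounds are considered here, and "the series" means these few. Any claim that something is new, unique, unknown or untested is made for them only; others in the source may bear on it.

- Compound 1 `Cc1ccc(OCC(=O)NNC(=O)c2cc3ccccc3oc2=O)c(C(=O)c2ccccc2)c1`: 87000 nM
- Compound 2 `Cc1ccc(OCC(=O)NNC(=O)c2cc3ccccc3oc2=O)c(C(=O)c2ccccc2Cl)c1`: 54400 nM

In a functional assay on DLA cells (Mus musculus) for cytotoxicity, read by LDH release, with a stated time of 48 h (on this read-out higher numbers stand for weaker inhibition and lower numbers for stronger inhibition), compound 2 gives 54400 nM, which lies within the usual scatter of compound 1, so neither stands apart. Compound 3 `Cc1ccc(OCC(=O)NNC(=O)c2cc3ccccc3oc2=O)c(C(=O)c2cccc(Br)c2)c1` is not yet measured. It has 3-bromophenyl in place of 2-chlorophenyl on a carbonyl carbon. Among the measured compounds shown here, the only measured step that bears on this, a 1.6-fold lower number from compound 1 to compound 2 (0.20 log units; within the scatter), put chloro in place of hydrogen on an aromatic carbon and stayed within the scatter. No step beyond the scatter is therefore expected in this assay. The estimated change is a 1.1-fold higher number from compound 2 to compound 3 (0.04 log units; within the scatter). For compound 3 the expected value is 60000 nM, with an estimated range of 30000 nM to 110000 nM.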

Compound 3, half-maximal inhibitory concentration: 69800 nM
Estimate against measurement, compound 3: 1.2-fold (0.07 log units) below, within the range that was stated.
By their numbers in this assay, from the lowest: compounds 2, 3 and 1 (each within the scatter of the next).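

In this assay the swap of 2-chlorophenyl for 3-bromophenyl on a carbonyl carbon gives a 1.3-fold higher number from compound 2 to compound 3 (0.11 log units; within the scatter) and the added bromo gives a 1.2-fold lower number from compound 1 to compound 3 (0.10 log units; within the scatter) and both steps stay within the usual scatter. So compounds 1, 2 and 3, with phenyl, 2-chlorophenyl and 3-bromophenyl, do not stand apart from one another here. Nothing at hand speaks to the reason for this.

On these data alone, whether an amine or a carboxylic acid on this phenyl would give a step beyond the scatter remains open.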